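Methyl on the furan of compound 1: solubility outlook

This account rests on a few compounds, and the source may have more. Where it says the series, first, only, none or still open, it means among the compounds named here.

These notes cover solubility in a physicochemical assay for solubility, read by mass spectrometry, in phosphate buffer, with a stated time of 24 h, at pH 7.4 (a higher number here means a more soluble compound, a lower number a less soluble compound), for a small urea series sharing one core. Compound 1 `O=C(Nc1ccc(OC(F)(F)F)cc1)NC1CCN(C(=O)c2ccoc2)CC1` gives 7.6 ug/mL in this assay. Compound 3 `CC(C)C(=O)N1CCC(NC(=O)Nc2ccc(OC(F)(F)F)c(F)c2)CC1` gives 5.3 ug/mL in this assay, a gap to compound 1 that lies within the scatter, so no order between the two can be claimed. Compound 2 `O=C(Nc1ccc(C(F)(F)F)cc1)NC1CCN(C(=O)C2=COCC2)CC1` gives 2.3 ug/mL in this assay, and here the gap to compound 1 is beyond the scatter. Compound 1 thus holds the highest number of the three, though only its separation from compound 2 is secure.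

Compound 4 `Cc1occc1C(=O)N1CCC(NC(=O)Nc2ccc(OC(F)(F)F)cc2)CC1` has not yet been measured. It differs from compound 1 as follows: methyl in place of hydrogen on an aromatic carbon. The change reads furan-3-yl to 2-methylfuran-3-yl. For the measured compounds named here, no pair of measured compounds isolates this change, so the expected step rests on the size of the added group alone. A small downward step, or none beyond the scatter, is expected as a 1.5-fold lower number from compound 1 to compound 4 (0.18 log units; within the scatter). For compound 4 the expected value in this assay is 5 ug/mL, with a range from 2.3 ug/mL to 11 ug/mL.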

Compound 4, solubility: 8.6 ug/mL
Estimate against measurement, compound 4: 1.7-fold (0.24 log units) below, and the stated range covers the measured number.
By their numbers in this assay, from the lowest: compound 2; then compounds 3, 1 and 4 (each within the scatter of the next).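

In this assay, for the compounds shown here, the first reading at this position is a 1.1-fold higher number from compound 1 to compound 4 (0.05 log units; within the scatter), for methyl in place of hydrogen on an aromatic carbon next to the ring oxygen. Going by these compounds alone, in this one pair, on the core of compound 1, the change from furan-3-yl to 2-methylfuran-3-yl therefore gives no step that can be told from the scatter. Nothing measured here bears on why the number stays put.

On these data alone, whether a longer chain such as ethyl, an amine or a carboxylic acid at this same carbon would also stay within the scatter remains open. A single pair also leaves open whether methyl would give a similar step on another urea of the series.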